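A few compounds are considered here, and "the series" means these few. Any claim that something is new, unique, unknown or untested is made for them only; others in the source may bear on it.

Working notes on the series in a functional assay on HT-1080 cells (Homo sapiens), read by transwell migration, with a stated time of 24 h, tested at 10 uM; on this read-out higher numbers stand for a weaker effect at the one concentration tested and lower numbers for a stronger effect. Of the compounds shown here, two carry numbers so far. Compound 1, `CC(=O)OCc1ccc2oc(=O)c(C(=O)Oc3cccc(Br)c3)cc2c1`, gives 11.8%. Compound 2, `CC(C)C(=O)OCc1ccc2oc(=O)c(C(=O)Oc3cccc(Br)c3)cc2c1`, gives 21.1%. Going by the values given here, the two differ in one place, isopropyl in place of methyl on a carbonyl carbon, and the only measured step is a number 9.3 percentage points higher from compound 1 to compound 2 (within the scatter); the two numbers lie within the usual scatter of each other, so they do not settle any order between compound 1 and compound 2.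

Compound 3, `CC(C)(C)C(=O)OCc1ccc2oc(=O)c(C(=O)Oc3cccc(Br)c3)cc2c1`, is not yet measured. It differs from compound 2 by methyl in place of hydrogen on a saturated chain carbon bound to a carbonyl carbon and two saturated chain carbons. Among the compounds with values here, the one measured step bears on this, since it likewise enlarged the alkyl group on the same carbonyl carbon, and it stayed within the scatter. Nothing else in the data speaks to this change. The expected step is therefore a number 3.9 percentage points higher from compound 2 to compound 3 (within the scatter), with perhaps a slight drift upward but nothing beyond the scatter. Compound 3 is accordingly estimated at 25%, with a range from 12% to 40%.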

Compound 3, a percentage reported as activity, at one concentration (the size of the read-out at that concentration, not a potency): 23.6%
Beside the measured number, compound 3's estimate is 1.4 percentage points above it; the range from low to high includes it.
By their numbers in this assay, from the lowest: compounds 1, 2 and 3 (each within the scatter of the next, the first and the last beyond it).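

In this assay, the change from isopropyl to tert-butyl gives a number 2.5 percentage points higher from compound 2 to compound 3 (within the scatter), so this added methyl settles no order between the two compounds. Going by these compounds alone, what is new appears across the whole set: tert-butyl in place of methyl on a carbonyl carbon gives a number 11.8 percentage points higher from compound 1 to compound 3 (beyond the scatter), the first step at this position to pass beyond the scatter, and its size is only modest. Two steps that each stay within the scatter thus add up to a separation that does not, and only the methyl and tert-butyl ends of the set can be told apart. The data at hand offer no explanation for this separation.

Still open, going by these compounds, is how this carbonyl carbon would respond to a substituent of a different kind, such as a longer straight chain, a phenyl ring or a chain carrying an amine, since the three compounds cover only methyl, isopropyl and tert-butyl. Also open, on these data alone, is whether the same separation between methyl and tert-butyl would hold if the rest of the structure, shared by all three compounds, were changed.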